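The compounds below may be only part of what the source reports. "The series", "measured", "known", "first", "only" and "open" are said of these compounds alone.

Measured in an ADME assay on HEK293 cells (Homo sapiens) for cytotoxicity, read by MTT assay, with a stated time of 3 days; a lower number here means a stronger inhibitor, a higher number a weaker inhibitor:
Compound 1 `COc1ccc(-c2ccccc2)cc1`: 17 ug/mL
Compound 2 `COc1ccc(-c2ccccc2)c(OC)c1`: 27 ug/mL

In this assay, compound 1 gives 17 ug/mL and compound 2 gives 27 ug/mL. These two values lie within the scatter of each other, so the data set no order between the two compounds.

Compound 3 `COc1ccc(-c2ccccc2)cc1OC` has not yet been measured. It differs from compound 1 by one change: methoxy in place of hydrogen on an aromatic carbon. This is methoxy in place of hydrogen on an aromatic carbon, ortho to a methoxy group and meta to a group of 6 heavy atoms.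

For the measured compounds named here, only one measured step bears on this change: a 1.6-fold higher number from compound 1 to compound 2 (0.20 log units; within the scatter). It is the same kind of exchange, made at a different place on the core, and it stays within the scatter. With that single step as the guide, no change beyond the scatter is expected in this assay, though a small drift to a higher number would match it. The expected step is a 1.3-fold higher number from compound 1 to compound 3 (0.11 log units; within the scatter). For compound 3 the estimated value is 22 ug/mL, with an expected range from 10 ug/mL to 50 ug/mL.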

Compound 3, half-maximal inhibitory concentration: 26 ug/mL
For compound 3 the middle estimate is 1.2-fold (0.07 log units) below the measured one, and the stated range covers the measured number.
By their numbers in this assay, from the lowest: compounds 1, 3 and 2 (each within the scatter of the next).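

In this assay, methoxy in place of hydrogen at this place, ortho to a methoxy group and meta to a group of 6 heavy atoms, gives a 1.5-fold higher number from compound 1 to compound 3 (0.18 log units; within the scatter) and stays within the scatter. The earlier step (a 1.6-fold higher number from compound 1 to compound 2 (0.20 log units; within the scatter)) came from the same exchange made at a different place on the core, so the exchange has now been read at two places on the core of compound 1, and neither reading leaves the scatter. For these two places, then, the added methoxy sets no order against compound 1, and nothing available offers an explanation for this result.

The compounds shown leave open whether a different group at this same place, such as an amine, a carboxylic acid or a longer alkoxy chain, would move the number beyond the scatter. They also leave open whether methoxy at other places on the core would do so, and what replacing the existing methoxy group of compound 1 with hydrogen would do in this assay.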